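Fluoro for chloro on the shared core: a step expected within scatter

The source may report more compounds than this note shows. Statements on the series, on what has been measured and on what is new or still open speak of the compounds shown alone.

Measured compounds in a functional assay on SW1573 cells (Homo sapiens) for inhibition, read by sulforhodamine B assay, with a stated time of 48 h; a higher number here means a weaker inhibitor of growth, a lower number a stronger inhibitor of growth:
compound 1 `COC(=O)[C@@]1(C)CCC=C2[C@@H]1CC[C@@H](C)[C@]2(C)Cc1c[nH]c2ccc(C)cc12` gives 15000 nM
compound 2 `COC(=O)[C@@]1(C)CCC=C2[C@@H]1CC[C@@H](C)[C@]2(C)Cc1c[nH]c2ccc(Br)cc12` gives 12000 nM
compound 3 `COC(=O)[C@@]1(C)CCC=C2[C@@H]1CC[C@@H](C)[C@]2(C)Cc1c[nH]c2ccc(Cl)cc12` gives 11000 nM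

The three compounds share one core and differ only in the group on the aromatic carbon of the six-membered aromatic ring of carbon only. Compound 3 has the lowest of the three numbers, but its gap to compound 2 and to compound 1 are both within the scatter, so the three cannot be ranked. Going by the values given here, the steps that bear on the new compound are a 1.3-fold lower number from compound 1 to compound 2 (0.10 log units; within the scatter), a 1.4-fold lower number from compound 1 to compound 3 (0.13 log units; within the scatter) and a 1.1-fold lower number from compound 2 to compound 3 (0.04 log units; within the scatter): every exchange of one group for another at this position left this assay essentially unchanged.

Compound 4 `COC(=O)[C@@]1(C)CCC=C2[C@@H]1CC[C@@H](C)[C@]2(C)Cc1c[nH]c2ccc(F)cc12` carries the change (fluoro in place of chloro on an aromatic carbon). It is the fourth such exchange at the same place. Because the earlier exchanges gave a 1.1-fold lower number from compound 2 to compound 3 (0.04 log units; within the scatter) and a 1.4-fold lower number from compound 1 to compound 3 (0.13 log units; within the scatter), no step beyond the scatter is expected, in either direction. The estimated step is a 1.1-fold higher number from compound 3 to compound 4 (0.04 log units; within the scatter). Compound 4 is therefore expected to give about 12000 nM in this assay, with a likely range from 6000 nM to 25000 nM.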

Compound 4, concentration for 50% growth inhibition: 7300 nM
Estimate against measurement, compound 4: 1.6-fold (0.22 log units) above, within the range that was stated.
By their numbers in this assay, from the lowest: compounds 4, 3, 2 and 1 (each within the scatter of the next, the first and the last beyond it).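

In this assay, fluoro in place of chloro stays within the scatter (a 1.5-fold lower number from compound 3 to compound 4 (0.18 log units; within the scatter)), as does fluoro in place of bromo (a 1.6-fold lower number from compound 2 to compound 4 (0.22 log units; within the scatter)), so the three halogens at this aromatic carbon still cannot be ranked against one another. Going by these compounds alone, the new information lies in the comparison with methyl: fluoro in place of methyl (a 2.1-fold lower number from compound 1 to compound 4 (0.31 log units; beyond the scatter)) is the first step at this position to pass the scatter, though only modestly, while the exchanges of methyl for bromo and for chloro remain within it, so the result separates only the two ends of the series and does not establish a trend across the halogens. Nothing measured here bears on why the fluoro compound sits at that end of the series.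

The compounds shown carry only methyl and three halogens at this carbon, so it remains open whether an amine, a carboxylic acid, a methoxy group or a longer chain there would give a step larger than this modest one. They also leave open how changes elsewhere on the shared core, such as replacing the methyl ester, would alter growth inhibition.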